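The source may hold more compounds than are shown below. What is called first, only, known or untested is meant among the compounds shown, and "the series" means these compounds.

Measured in an ADME assay on Huh-7 cells (Homo sapiens) for cytotoxicity, read by MTT assay, with a stated time of 72 h; a lower number here means that less compound is tolerated, a higher number that more compound is tolerated:

Compound 1 `Cc1ccccc1C(=O)NO`: 650000 nM
Compound 2 `COc1cccc(C(=O)NO)c1`: 570000 nM

In this assay, compound 1 stands at 650000 nM, and compound 2 at 570000 nM lies within the scatter of it, so the two numbers do not separate. Compound 3 `CCCCOc1ccccc1C(=O)NO` has not yet been measured. It departs from compound 1 in one place, with butoxy in place of methyl on an aromatic carbon, ortho to a group of 4 heavy atoms: butoxy in place of methyl on an aromatic carbon. Within the data shown here, no measured pair shows this change, so the expectation rests on judgement alone. A moderate move toward a lower number is expected, meaning less compound tolerated, although a step within the scatter remains possible. The expected change is a 2.6-fold lower number from compound 1 to compound 3 (0.41 log units; beyond the scatter). Compound 3 is estimated at 250000 nM, within an expected range of 80000 nM to 600000 nM.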

Compound 3, half-maximal cytotoxic concentration: 380000 nM
Compound 3: the middle estimate sits 1.5-fold (0.18 log units) below what was measured; the range from low to high includes it.
By their numbers in this assay, from the lowest: compounds 3, 2 and 1 (each within the scatter of the next).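

Exchanging methyl for butoxy on an aromatic carbon, ortho to a group of 4 heavy atoms, gives a 1.7-fold lower number from compound 1 to compound 3 (0.23 log units; within the scatter) in this assay, so at this position the much larger group does not separate compound 3 from compound 1. Among these compounds, compound 1 and compound 2 offered no such single-place comparison, and this step is the first reading of any change at this position. Nothing available explains the size of this step or ties it to either group.

What remains open is whether the added oxygen or the four-carbon chain contributes more to the step, since the compounds shown change both together. From the compounds shown here alone, it is also open whether an amine, a carboxylic acid or a longer chain at this position would give a step beyond the scatter.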